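The source may report more compounds than this note shows. Statements on the series, on what has been measured and on what is new or still open speak of the compounds shown alone.

Compound 1 `Cn1ccc2c(Oc3ccc(NC(=O)c4nn(-c5ccccc5)ccc4=O)cc3)ccnc21`: 51700 nM
Compound 2 `Cn1ccc2c(Oc3ccc(NC(=O)c4nn(-c5ccc(Br)cc5F)ccc4=O)cc3)ccnc21`: 35700 nM
Compound 3 `Cn1ccc2c(Oc3ccc(NC(=O)c4nn(-c5ccc(Cl)c(C(F)(F)F)c5)ccc4=O)cc3)ccnc21`: 11400 nM

The three measured compounds share one core and differ only in the group carried on an aromatic nitrogen. In a functional assay on A549 cells (Homo sapiens) for cytotoxicity, read by MTT assay, with a stated time of 72 h (on this read-out lower numbers stand for stronger inhibition and higher numbers for weaker inhibition), compound 2 gives 35700 nM, the second highest of the three numbers. Its nearest neighbour is compound 1, which in this assay gives 51700 nM; here a 1.4-fold lower number from compound 1 to compound 2 (0.16 log units; within the scatter). Compound 3 gives 11400 nM in this assay, and a 3.1-fold lower number from compound 2 to compound 3 (0.50 log units; beyond the scatter), while a 4.5-fold lower number from compound 1 to compound 3 (0.66 log units; beyond the scatter).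

Compound 4 `Cn1ccc2c(Oc3ccc(NC(=O)c4nn(-c5ccc(Br)cc5F)ccc4=O)cc3F)ccnc21` is not yet measured. It keeps the 4-bromo-2-fluorophenyl of compound 2 and differs from it in one place: fluoro in place of hydrogen on an aromatic carbon, on an aromatic carbon of a six-membered aromatic ring of carbon only, ortho to a large group and meta to a large group. None of the three measured steps bears on this change: each of them exchanges the group on the aromatic nitrogen, and none adds a fluoro to a ring of the core. No direction can therefore be read from the data, and compound 4 is expected to stay within the scatter of compound 2, with a 1.0-fold lower number from compound 2 to compound 4 (0.01 log units; within the scatter). Compound 4 is accordingly estimated at 35000 nM in this assay, with a range from 15000 nM to 80000 nM.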

Compound 4, half-maximal inhibitory concentration: 26800 nM
The estimate for compound 4 lay 1.3-fold (0.12 log units) above the measured number, within the range that was stated.
By their numbers in this assay, from the lowest: compound 3; then compounds 4, 2 and 1 (each within the scatter of the next).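

In this assay, fluoro in place of hydrogen on an aromatic carbon, ortho to a large group and meta to a large group, gives a 1.3-fold lower number from compound 2 to compound 4 (0.12 log units; within the scatter) and so cannot be told apart from compound 2 while the 4-bromo-2-fluorophenyl stays in place. This is the only step shown that touches the shared core rather than the group on the aromatic nitrogen, and unlike the two steps to compound 3, which lie beyond the scatter, it stays within it. Nothing at hand explains why this step is so slight.

The compounds shown leave open whether the same fluoro would also stay within the scatter when the group on the aromatic nitrogen is the 4-chloro-3-(trifluoromethyl)phenyl of compound 3, since this step is read on one group alone. They also leave open how this aromatic carbon would respond to something other than fluoro, such as a chloro, a methoxy or an amine.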